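The source may report more compounds than this note shows. Statements on the series, on what has been measured and on what is new or still open speak of the compounds shown alone.

Measured compounds:
- compound 1 `COc1ccc(-c2nc(CNc3ccc(C(=O)NO)cc3)n(-c3ccccc3)n2)cc1`: 77.6%
- compound 2 `Cc1ccccc1-c1nc(CNc2ccc(C(=O)NO)cc2)n(-c2ccccc2)n1`: 53.2%
- compound 3 `O=C(NO)c1ccc(NCc2nc(-c3ccncc3)nn2-c2ccccc2)cc1`: 30.8%

In an assay on Sf9 cells for inhibition of protein deacetylase HDAC6 (Homo sapiens), read by fluorescence, with a stated time of 40 min, tested at 100 nM (a lower number here means less inhibition, a higher number more inhibition at the concentration tested (going by the name of the read-out)), compound 3 gives the lowest of the three numbers; compound 2 sits closest to it and compound 1 furthest above it. The measured steps all point the same way: a number 24.4 percentage points lower from compound 1 to compound 2 (beyond the scatter), a number 22.4 percentage points lower from compound 2 to compound 3 (beyond the scatter), and a number 46.8 percentage points lower from compound 1 to compound 3 (beyond the scatter). Compound 4 `CC(C)c1ccc(-c2nc(CNc3ccc(C(=O)NO)cc3)n(-c3ccccc3)n2)cc1` has not yet been measured; it differs from compound 3 in one place: 4-isopropylphenyl in place of pyridin-4-yl on an aromatic carbon.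

Going by the values given here, the steps that bear on this change are those involving compound 3, since both replace the pyridin-4-yl group with a carbon-only ring, or the reverse. Going from pyridin-4-yl to 2-methylphenyl raised the read-out by a modest amount, and going from pyridin-4-yl to 4-methoxyphenyl raised it by a large amount. Compound 4 carries a carbon-only ring as compound 1 and compound 2 do, so the step from compound 3 is expected to be upward and beyond the scatter. Compound 4 is therefore estimated at 65%, within a range from 45% to 85%. The estimate amounts to an expected a number 34.2 percentage points higher from compound 3 to compound 4 (beyond the scatter).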

Compound 4, a percentage reported as inhibition, at one concentration (the size of the read-out at that concentration, not a potency): 27.6%
Compound 4: middle estimate off by 37.4 percentage points, on the high side, outside the stated range (below it).
By their numbers in this assay, from the lowest: compounds 4 and 3 (each within the scatter of the next); then compound 2; then compound 1.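

In this assay the step from pyridin-4-yl to 4-isopropylphenyl is a number 3.2 percentage points lower from compound 3 to compound 4 (within the scatter) so a ring of carbon only at this position does not by itself set the read-out apart from a ring with one nitrogen. What the carbon-only ring carries proves to matter, as isopropyl in place of methoxy gives a number 50 percentage points lower from compound 1 to compound 4 (beyond the scatter) and 4-isopropylphenyl in place of 2-methylphenyl gives a number 25.6 percentage points lower from compound 2 to compound 4 (beyond the scatter) which shows that three compounds with a carbon-only ring at this aromatic carbon spread widely, while compound 3, with its pyridin-4-yl, offers no contrast with compound 4. Nothing in the data at hand accounts for the gap between the methoxy and isopropyl compounds.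

On these data alone, it remains open whether the read-out follows the particular group on the phenyl ring or its size, and a hydroxy group, an amine or an ethyl group in the same place would help to separate these. As far as these compounds go, since each number is a percentage at a single concentration, the compounds' potencies also remain unknown, and compound 3 and compound 4 may or may not differ at other concentrations.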